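Piperazine Replacement at the Amine Position of Compound 1

The source may hold more compounds than are shown below. What is called first, only, known or untested is meant among the compounds shown, and "the series" means these compounds.

Measured compounds:
compound 1 `CCC1(O)CCN(c2nc(C)c3cc(NC(=O)COc4ccc(OC(F)(F)F)cc4)ccc3n2)CC1` — 116 nM
compound 2 `Cc1nc(N2CCC(C(=O)NC(C)C)CC2)nc2ccc(NC(=O)COc3ccc(Cl)cc3)cc12` — 15 nM

In an assay on CHO-K1 cells for displacement of a labelled ligand from melanin-concentrating hormone receptor 1 (Homo sapiens), with a stated time of 2 h (on this read-out higher numbers stand for weaker inhibition and lower numbers for stronger inhibition), compound 1 gives 116 nM, the highest of the two numbers measured. The nearest measured neighbour is compound 2, which in this assay gives 15 nM, a gap that lies beyond the usual scatter; the two compounds differ in more than one place, so their values are compared only as they stand. Compound 3 `Cc1nc(N2CCN(C3CCOCC3)CC2)nc2ccc(NC(=O)COc3ccc(OC(F)(F)F)cc3)cc12` carries the change (4-(oxan-4-yl)piperazin-1-yl in place of 4-ethyl-4-hydroxypiperidin-1-yl on an aromatic carbon), a 4-(oxan-4-yl)piperazin-1-yl in place of 4-ethyl-4-hydroxypiperidin-1-yl on an aromatic carbon. For the measured compounds named here, no measured pair shows this single change, so the expectation rests on compound 1 alone. The author expects a moderate step toward stronger inhibition, a 2.9-fold lower number from compound 1 to compound 3 (0.46 log units; beyond the scatter), since compound 2 shows that lower numbers are reachable within this series. For compound 3 the estimated value in this assay is 40 nM, with a range from 10 nM to 150 nM.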

Compound 3, half-maximal inhibitory concentration: 7 nM
For compound 3 the middle estimate is 5.7-fold (0.76 log units) above the measured one, outside the stated range (below it).
By their numbers in this assay, from the lowest: compound 3; then compound 2; then compound 1.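

Placing 4-(oxan-4-yl)piperazin-1-yl on the aromatic carbon between two ring nitrogen atoms, with the rest of compound 1 unchanged, gives a 17-fold lower number from compound 1 to compound 3 (1.22 log units; beyond the scatter) in this assay. This first single change read at this position shows that the position accepts a larger group with two rings, and that the hydroxy group of 4-ethyl-4-hydroxypiperidin-1-yl is not needed for a low number in this series. The data shown give no measurement that would explain the size of this step.

The compounds shown leave open whether the step follows from the piperazine ring or from the oxane ring attached to it, a question that a plain piperazin-1-yl or a 4-methylpiperazin-1-yl at the same position would address. They also leave open how much of the step would remain with other groups elsewhere on the shared core.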